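Diisopropylcarbamoyl in place of pyrrolidinylmethyl on the ring

This account rests on a few compounds, and the source may have more. Where it says the series, first, only, none or still open, it means among the compounds named here.

Three members of the series have numbers in a functional assay on A549 cells (Homo sapiens) for antiproliferative activity, read by MTT assay, with a stated time of 48 h; on this read-out lower numbers stand for stronger inhibition and higher numbers for weaker inhibition. Compound 1 `CC(=O)OC/C1=C/C[C@](C)(CCC=C(C)C)/C=C/[C@@H](OC(=O)C=C(C)C)[C@](C)(OC(C)=O)/C=C/C1=O` gives 15100 nM. Compound 2 `CC(C)=CCC[C@]1(C)/C=C/[C@@H](OC(=O)C=C(C)C)[C@](C)(O)/C=C/C(=O)/C(CN2CCCC2)=C\C1` gives 180 nM, the lowest of the three numbers. Compound 3 `CC(C)=CCC[C@]1(C)/C=C/[C@@H](OC(=O)C=C(C)C)[C@](C)(O)/C=C/C(O)/C(C=O)=C\C1` gives 570 nM, which stands beyond the scatter from compound 2, and the number for compound 1 stands far beyond it; compound 2 is thus the strongest inhibitor among the three measured.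

Compound 4 `CC(C)=CCC[C@]1(C)/C=C/[C@@H](OC(=O)C=C(C)C)[C@](C)(O)/C=C/C(=O)/C(C(=O)N(C(C)C)C(C)C)=C\C1` awaits measurement in this assay. It differs from compound 2 in one place: diisopropylcarbamoyl in place of (pyrrolidin-1-yl)methyl on a double-bonded ring carbon. The group that leaves contains a ring and the group that enters contains none, and an oxygen is added at the same position. Going by the values given here, no pair of measured compounds shows this change, so no measured step can be drawn on; the only guide is that compound 1 with 15100 nM and compound 3 with 570 nM both lie above compound 2. A moderate loss beyond the scatter is expected, with the step from compound 2 to compound 4 estimated at a 3.3-fold higher number from compound 2 to compound 4 (0.52 log units; beyond the scatter). Compound 4 is expected to give 600 nM, within a range of 150 nM to 2500 nM.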

Compound 4, half-maximal inhibitory concentration: 13500 nM
Compound 4: the middle estimate sits 23-fold (1.35 log units) below what was measured; measured number above the stated range.
By their numbers in this assay, from the lowest: compound 2; then compound 3; then compounds 4 and 1 (each within the scatter of the next).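

In this assay, the substituent on the double-bonded ring carbon carries much of the activity: diisopropylcarbamoyl in place of (pyrrolidin-1-yl)methyl gives a 75-fold higher number from compound 2 to compound 4 (1.88 log units; beyond the scatter). Going by these compounds alone, this is the only step that changes one place alone, so the sensitivity of this position can now be read directly, with the hydroxy group and the ((2-methylprop-1-en-1-yl)carbonyl)oxy group held constant. No measurement is available that bears on the origin of this step.

Within the data shown here, the single pair does not separate the added carbonyl from the lost ring or from the swap of pyrrolidine for two isopropyl groups. Pyrrolidine-1-carbonyl and (diisopropylamino)methyl at the same carbon would each change only one of these features, and the outcome for either remains open.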